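A few compounds are considered here, and "the series" means these few. Any claim that something is new, unique, unknown or untested is made for them only; others in the source may bear on it.

Measured so far in an ADME assay on Vero cells (Chlorocebus sabaeus) for cytotoxicity, read by neutral red uptake, tested at 394 ug/mL; on this read-out lower numbers stand for a stronger effect and higher numbers for a weaker effect at the one concentration tested:
compound 1 `COc1ccccc1C1SCC(=O)N1CCN1CCCCC1` — 67%
compound 2 `COc1cccc(C2SCC(=O)N2CCN2CCCCC2)c1` — 57%

Compound 1 gives 67% in this assay, and compound 2 gives 57%; the two numbers lie within the usual scatter of each other, so neither can be told apart from the other on this read-out. The account now follows the step from compound 1 to compound 3 `O=C1CSC(c2ccccc2Cl)N1CCN1CCCCC1`, which has not yet been measured. The change is chloro in place of methoxy on an aromatic carbon. For the measured compounds named here, no step between measured compounds exists to set the size of such a change, and the two measured compounds leave the question open. For compound 3 the expectation is therefore no step beyond the scatter: a number 5 percentage points lower from compound 1 to compound 3 (within the scatter) is the estimated move. Compound 3 is expected to give about 62%, with a range from 40% to 85%.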

Compound 3, a percentage reported as activity, at one concentration (the size of the read-out at that concentration, not a potency): 31%
Beside the measured number, compound 3's estimate is 31 percentage points above it, outside the stated range (below it).
By their numbers in this assay, from the lowest: compound 3; then compounds 2 and 1 (each within the scatter of the next).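

In this assay, putting chloro in place of methoxy on an aromatic carbon ortho to a large group gives a number 36 percentage points lower from compound 1 to compound 3 (beyond the scatter), so at this place the read-out responds clearly to a single change of group. For the compounds shown here, this is the first step that lies beyond the scatter, and it shows a stronger effect at the one concentration tested, with the rest of the molecule unchanged. Nothing available explains why this exchange has so large an effect.

The compounds shown leave open whether the step depends on chloro itself or on the removal of methoxy, which a hydrogen, a fluoro or a methyl at the same place could separate. They also leave open whether chloro on another aromatic carbon of this ring would give a step of similar size.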